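The source may hold more compounds than are shown below. What is called first, only, known or untested is meant among the compounds shown, and "the series" means these compounds.

Working notes on the series

Compound 1 `C=C1[C@@H](O)[C@H](n2cnc3c(N)nc(N)nc32)O[C@@H]1CO` and compound 2 `C=C1[C@@H](O)[C@H](n2cnc3c(O)nc(N)nc32)O[C@@H]1CO` share one core; compound 3 `C=C1[C@H](n2cnc3c(N)nc(N)nc32)O[C@H](CO)[C@H]1O` and the unmeasured compound 4 `C=C1[C@H](n2cnc3c(O)nc(N)nc32)O[C@H](CO)[C@H]1O` share another, built from the same atoms joined differently. The difference between the two cores is not broken down here.

In a functional assay on MT4 cells (Homo sapiens) for inhibition (on this read-out lower numbers stand for stronger inhibition and higher numbers for weaker inhibition), compound 1 gives > 200000 nM, a limit of the assay and not a number. In this assay compound 2 gives > 200000 nM, again a limit. The change from compound 1 to compound 2 is hydroxy in place of amino on an aromatic carbon; the step that the two limits leave unreadable from compound 1 to compound 2 therefore cannot be read from the two limits. Both of these values sit at the limit of > 200000 nM in this assay, at which 2 of the 3 values shown sit.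

In this assay compound 3 gives > 500000 nM, also a limit and not a number; it sits at the limit of > 500000 nM in this assay, at which 1 of the 3 values shown sits.

Among the compounds with values here, compound 4 arises from compound 3 by hydroxy in place of amino on an aromatic carbon, the same change as the one from compound 1 to compound 2, since the surroundings of the place are described in identical words. No readable size exists for that change in this assay, so the step from compound 3 to compound 4 is expected to be a number no higher from compound 3 to compound 4 (the limit leaves the size open), resting on the fact that compound 3 reports only the limit > 500000 nM and that compound 1 and compound 2 both sit at the limit of > 200000 nM in this assay, at which 2 of the 3 values shown sit. The value of compound 4 in this assay is accordingly estimated at 500000 nM, within 200000 nM to 2000000 nM, most likely reported as a limit again.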

Compound 4, half-maximal inhibitory concentration: 150000 nM
Estimate against measurement, compound 4: 3.3-fold (0.52 log units) above, and the stated range ends above it.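

In this assay, hydroxy in place of amino on an aromatic carbon gives an at least 3.3-fold lower number from compound 3 to compound 4 (0.52 log units; beyond the scatter) on the core of compound 3, a size that rests on a limit and not a number for compound 3. On the core of compound 1 the same change cannot be read, since compound 1 and compound 2 both report a limit and not a number: the limit of > 200000 nM in this assay, at which 2 of the 4 values shown sit. Carrying the change from one core to the other is therefore neither confirmed nor refuted, as the lower number is readable on the core of compound 3 alone and no size exists on the core of compound 1 to set beside it.

The compounds shown leave open whether another group on the same aromatic carbon, such as methoxy, chlorine or a methylamino group, would move the number further than hydroxy does in this pair. They also leave open how the difference between the two cores itself bears on the read-out, and whether the step seen on the core of compound 3 would keep its size if compound 3 gave a number rather than a limit.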